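A few compounds are considered here, and "the series" means these few. Any claim that something is new, unique, unknown or untested is made for them only; others in the source may bear on it.

Compound 1, `O=C(CSc1nc(Nc2ccccc2)c2ccccc2n1)Nc1ccccc1F`, gives 10700 nM in a functional assay on MGC-803 cells (Homo sapiens) for inhibition, read by MTT assay, with a stated time of 72 h; a higher number here means a weaker inhibitor, a lower number a stronger inhibitor.
Compound 2, `O=C(CSc1nc(Nc2ccccc2)c2ccccc2n1)Nc1cccc(F)c1`, gives 12700 nM in the same test.

Among the measured compounds shown here, compound 2 stands level with compound 1: the one measured step, a 1.2-fold higher number from compound 1 to compound 2 (0.07 log units; within the scatter), is within the scatter, so the two cannot be ranked. Compound 3, `O=C(CSc1nc(Nc2ccccc2)c2ccccc2n1)Nc1cccc(Br)c1`, carries bromo in place of fluoro on an aromatic carbon. For the measured compounds named here, no measured step exchanges one halogen for another, so nothing bears directly on this change; the only step measured was small. Compound 3 is therefore expected to stay close to compound 2, the expected step being a 1.3-fold lower number from compound 2 to compound 3 (0.10 log units; within the scatter). The estimate for compound 3 is 10000 nM, with a range from 4000 nM to 25000 nM.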

Compound 3, half-maximal inhibitory concentration: 9620 nM
Compound 3: middle estimate off by 1.0-fold (0.02 log units), on the high side; low and high end bracket the measured number.
By their numbers in this assay, from the lowest: compounds 3, 1 and 2 (each within the scatter of the next).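

Bromo in place of fluoro on this aromatic carbon gives a 1.3-fold lower number from compound 2 to compound 3 (0.12 log units; within the scatter) in this assay, so the exchange of one halogen for another leaves no readable mark at this position. The comparison with the other fluoro compound, a 1.1-fold lower number from compound 1 to compound 3 (0.05 log units; within the scatter), is also within the scatter, and the three compounds cannot be ranked. Nothing available explains this result.

The compounds shown carry only fluoro and bromo on this ring. From the compounds shown here alone, whether a methoxy group, an amine or a carboxylic acid at this place would shift the number stays open.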